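The source may report more compounds than this note shows. Statements on the series, on what has been measured and on what is new or still open speak of the compounds shown alone.

Three compounds share one core and differ only in the aryl group on the double-bonded chain. In an ADME assay on the whole organism for cytotoxicity, with Artemia salina as the target, with a stated time of 24 h (on this read-out lower numbers stand for an effect already at smaller amounts and higher numbers for an effect only at larger amounts of compound), compound 1 `Cc1ccc(S(=O)(=O)NC(=O)Nc2ccccc2C(=O)/C=C/c2ccc(N(C)C)cc2)cc1` gives 38.1 ug/mL, compound 2 `COc1ccc(/C=C/C(=O)c2ccccc2NC(=O)NS(=O)(=O)c2ccc(C)cc2)c(OC)c1` gives 16 ug/mL, and compound 3 `Cc1ccc(S(=O)(=O)NC(=O)Nc2ccccc2C(=O)/C=C/c2ccc(O)cc2)cc1` gives 24.3 ug/mL, the middle of the three numbers, though within the scatter of the other two. Compound 4 `Cc1ccc(S(=O)(=O)NC(=O)Nc2ccccc2C(=O)/C=C/c2cccc([N+](=O)[O-])c2)cc1` carries the change (3-nitrophenyl in place of 4-hydroxyphenyl on a double-bonded chain carbon bound to a double-bonded chain carbon). Earlier exchanges at this same place gave a 2.4-fold lower number from compound 1 to compound 2 (0.38 log units; beyond the scatter), a 1.6-fold lower number from compound 1 to compound 3 (0.20 log units; within the scatter) and a 1.5-fold higher number from compound 2 to compound 3 (0.18 log units; within the scatter), so swapping the aryl group has so far moved the read-out only a little. The step of a 1.0-fold higher number from compound 3 to compound 4 (0.01 log units; within the scatter) is therefore expected to stay small, with no clear direction. Compound 4 is estimated to give 25 ug/mL, within a range from 10 ug/mL to 60 ug/mL.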

Compound 4, concentration for half-maximal effect: 44.5 ug/mL
Compound 4: middle estimate off by 1.8-fold (0.25 log units), on the low side; measured number inside the range.
By their numbers in this assay, from the lowest: compounds 2, 3, 1 and 4 (each within the scatter of the next, the first and the last beyond it).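

Replacing 4-hydroxyphenyl with 3-nitrophenyl leaves the number close to those of the other aryl groups: a 1.8-fold higher number from compound 3 to compound 4 (0.26 log units; within the scatter) and a 1.2-fold higher number from compound 1 to compound 4 (0.07 log units; within the scatter) both stay within the scatter. Only the comparison with the 2,4-dimethoxyphenyl group stands beyond it, with a 2.8-fold higher number from compound 2 to compound 4 (0.44 log units; beyond the scatter), and even this step is modest. Nothing available here explains these small differences.

Going by these compounds, it remains open whether an unsubstituted phenyl, a 4-nitrophenyl or a ring carrying a carboxylic acid would stay within this narrow band. On these data alone, the effect of changes elsewhere on the shared core also remains open.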